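The source may hold more compounds than are shown below. What is called first, only, known or untested is meant among the compounds shown, and "the series" means these compounds.

Working notes on the series. Compound 1 `O=C1Nc2ccc(C(=O)c3ccco3)cc2/C1=C/c1cc(Br)c(O)c(Br)c1`, compound 2 `O=C1Nc2ccc(C(=O)c3ccco3)cc2/C1=C/c1ccnc(Cl)c1` and compound 3 `COc1ccc(/C=C2\C(=O)Nc3ccc(C(=O)c4ccco4)cc32)cc1Br` share one core and differ only in the aryl group on a double-bonded chain carbon bound to a double-bonded ring carbon. In an assay on HeLa cells for inhibition of Kinesin-like protein KIF15 (Homo sapiens), read by microscopy, with stated times of 2 s and 20 s, tested at 750 nM (on this read-out lower numbers stand for less inhibition and higher numbers for more inhibition at the one concentration tested (going by the name of the read-out)), compound 1 gives 65%, compound 2 gives 15.8% and compound 3 gives 2.3%. Compound 3 thus stands lowest of the three measured numbers, with compound 2 nearest to it and compound 1 furthest away, both gaps beyond the scatter. The measured steps are a number 49.2 percentage points lower from compound 1 to compound 2 (beyond the scatter), a number 62.7 percentage points lower from compound 1 to compound 3 (beyond the scatter) and a number 13.5 percentage points lower from compound 2 to compound 3 (beyond the scatter).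

For the measured compounds named here, compound 4 `O=C1Nc2ccc(C(=O)c3ccco3)cc2/C1=C/c1ccncc1` is the next member to be measured. pyridin-4-yl in place of 3-bromo-4-methoxyphenyl on a double-bonded chain carbon bound to a double-bonded ring carbon The one measured step that bears on this change runs in the opposite direction, a six-membered ring with one nitrogen replaced by a carbon-only ring: a number 13.5 percentage points lower from compound 2 to compound 3 (beyond the scatter). The entering pyridin-4-yl lacks the chlorine present in compound 2, so the reversed step serves as a guide rather than a fixed amount. A modest rise in this assay, of a size near the scatter or a little beyond it, is therefore expected for compound 4, a number 9.7 percentage points higher from compound 3 to compound 4 (within the scatter). For compound 4 the estimate in this assay is 12%, within a range from 0% to 28%.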

Compound 4, a percentage reported as inhibition, at one concentration (the size of the read-out at that concentration, not a potency): 0.8%
The estimate for compound 4 lay 11.2 percentage points above the measured number, within the range that was stated.
By their numbers in this assay, from the lowest: compounds 4 and 3 (each within the scatter of the next); then compound 2; then compound 1.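

In this assay, the step of a number 1.5 percentage points lower from compound 3 to compound 4 (within the scatter) stays within the scatter, so at this position the bare pyridin-4-yl cannot be told apart from the carbon-only 3-bromo-4-methoxyphenyl, and having a ring with one hetero atom gives no rise by itself. For the compounds shown here, two further steps set the limits of the series: the chloro group of compound 2 matters by a modest amount, with hydrogen in its place giving a number 15 percentage points lower from compound 2 to compound 4 (beyond the scatter), while the return to the group of compound 1 remains by far the largest change, seen in a number 64.2 percentage points lower from compound 1 to compound 4 (beyond the scatter), leaving 3,5-dibromo-4-hydroxyphenyl as the only aryl group of the four with a high number. No measurement bearing on the reason for any of these steps is at hand.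

Open, going by these compounds, is how much of the number of compound 1 rests on the hydroxyl and how much on the two bromines, a question that a 4-hydroxyphenyl without bromine or a 3,5-dibromo-4-methoxyphenyl would address. Also open, on these data alone, is whether an amine in place of chloro on an aromatic carbon would keep, lose or raise the small inhibition seen with the chloropyridine.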